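The compounds below may be only part of what the source reports. "The series", "measured", "known", "first", "only" and "open" are said of these compounds alone.

Compound 1 `CN(C(=O)NC(=O)c1cccc(C(F)(F)F)c1)c1nc(C(F)(F)F)c(C(=O)N/N=C/c2ccc(C(F)(F)F)cc2)s1` gives 6.5 ug/mL in a functional assay on MCF7 cells (Homo sapiens) for inhibition, read by MTT assay, with a stated time of 72 h; a higher number here means a weaker inhibitor, a lower number a stronger inhibitor.
Compound 2 `CNc1nc(C)c(C(=O)N/N=C/c2ccc(C(F)(F)F)cc2)s1` gives a limit, > 100 ug/mL, in this assay.
Compound 3 `CN(C(=O)NC(=O)c1ccccc1F)c1nc(C(F)(F)F)c(C(=O)N/N=C/c2ccc(C(F)(F)F)cc2)s1` gives 4.98 ug/mL in this assay.

Among the numbers shown, compound 3 and compound 1 lie within the scatter of each other; the only measured step is a 1.3-fold lower number from compound 1 to compound 3 (0.12 log units; within the scatter). Compound 4 `CNc1nc(C(F)(F)F)c(C(=O)N/N=C/c2ccc(C(F)(F)F)cc2)s1` is not yet measured; the change from compound 3 is hydrogen in place of ((2-fluorophenyl)carbonyl)carbamoyl on a nitrogen on an aromatic ring. For the measured compounds named here, no measured step removes this group, so the measured step gives no guide to its size. What the data do show is that compound 2, which also carries hydrogen on that nitrogen, sits at the limit of > 100 ug/mL in this assay, at which 1 of the 3 values shown sits. Compound 4 is therefore expected to be a much weaker inhibitor than compound 3, with an expected step of a 16-fold higher number from compound 3 to compound 4 (1.21 log units; beyond the scatter). The estimate for compound 4 is 80 ug/mL, in a range from 20 ug/mL to 300 ug/mL, with a fair chance that only a limit is reported.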

Compound 4, half-maximal inhibitory concentration: > 100 ug/mL
Compound 4 was reported as a limit; the forecaster's own chance of this, stated with the estimate: 60%; at least 1.2-fold (0.09 log units) between middle value and limit.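

Replacing ((2-fluorophenyl)carbonyl)carbamoyl with hydrogen on this nitrogen gives an at least 20-fold higher number from compound 3 to compound 4 (1.30 log units; beyond the scatter) in this assay, so this change now has a measured lower bound on its size. Compound 2 and compound 4 both stand at a limit, so the step from methyl to trifluoromethyl on the aromatic carbon cannot be read: the limit of > 100 ug/mL in this assay, at which 2 of the 4 values shown sit.

The compounds shown leave open how much of the removed group is needed. An acetyl group or a plain carbamoyl on this nitrogen could show whether a smaller piece still gives a measurable number.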